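The source may hold more compounds than are shown below. What is called first, only, known or untested is meant among the compounds shown, and "the series" means these compounds.

Measured compounds in a functional assay on L1210 cells (Mus musculus) for cytotoxicity, with a stated time of 48 h; on this read-out higher numbers stand for weaker inhibition and lower numbers for stronger inhibition:
compound 1 `Clc1ccc(Cc2nn3c(Br)c(-c4ccc(Br)cc4)nc3s2)cc1`, a value that is a limit of the assay: > 250000 nM.
compound 2 `Cc1ccc(-c2nc3sc(Cc4ccc(Cl)cc4)nn3c2Br)cc1`, likewise a limit of the assay: > 250000 nM.

Compound 2 stands only at a limit in this assay. Among the measured compounds shown here, the single measured step, a step that the two limits leave unreadable from compound 1 to compound 2, cannot be read because of the limit of > 250000 nM in this assay, at which 2 of the 2 values shown sit. Compound 3 `Cc1ccc(-c2nc3sc(Cc4ccc(Cl)cc4)nn3c2SC#N)cc1` differs from compound 2 by cyanosulfanyl in place of bromo on an aromatic carbon. For the measured compounds named here, no measured step bears on this change, so no direction beyond the scatter is expected, and a further limit is the likely report. Compound 3 is expected to give 250000 nM in this assay, between 50000 nM and 1000000 nM, an expected step of a number no higher from compound 2 to compound 3 (the limit leaves the size open).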

Compound 3, half-maximal inhibitory concentration: 32000 nM
For compound 3 the middle estimate is 7.8-fold (0.89 log units) above the measured one; the measured number lies below the stated range.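

In this assay, the bromo position on the five-membered aromatic ring responds to substitution: cyanosulfanyl in place of bromo gives an at least 7.8-fold lower number from compound 2 to compound 3 (0.89 log units; beyond the scatter). That size is only a lower bound, since compound 2 sits at a limit of the assay: the limit of > 250000 nM in this assay, at which 2 of the 3 values shown sit.

Among the compounds shown here, the same limit leaves the step between compound 1 and compound 2 unreadable, so this is the only readable change.

Open, as far as these compounds go, is whether the sulfur or the nitrile part carries the shift, which a methylsulfanyl group or a nitrile at this position would separate. Also open, from the compounds shown here alone, is whether the shift holds with the 4-bromophenyl group of compound 1.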